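Chloro for methyl on the pyridyl-amine series: cytotoxicity notes

This account rests on a few compounds, and the source may have more. Where it says the series, first, only, none or still open, it means among the compounds named here.

The series shares one core, seen in compound 1 `Cc1ccc(Nc2nc(-c3ccccn3)cs2)cc1C` and compound 2 `Cc1ccc(Nc2nc(-c3ccccn3)cs2)nc1`. Both were run in an ADME assay on KB cells (Homo sapiens) for cytotoxicity, read by MTT assay, with a stated time of 72 h; on this read-out higher numbers stand for lower toxicity in this test and lower numbers for higher toxicity in this test. In this assay compound 1 gives 54400 nM, and compound 2 gives 34300 nM. Of the two numbers, that of compound 2 is the lower one, but the gap to compound 1 lies within the usual scatter, so the two compounds cannot be separated on these data and neither can be called more or less toxic than the other.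

Compound 3 `Clc1ccc(Nc2nc(-c3ccccn3)cs2)nc1` follows from compound 2 by a single change: chloro in place of methyl on an aromatic carbon. Among the compounds with values here, no step between two measured compounds of this kind is available here, so the size of the move has to be judged from the change alone. A swap of one heavy atom for another, with no change in ring count, donors, acceptors or charge, gives no ground to expect a step beyond the scatter in this assay in either direction.

Compound 3 is therefore expected to give about 30000 nM, within a range of 12000 nM to 80000 nM; the estimated step of a 1.1-fold lower number from compound 2 to compound 3 (0.06 log units; within the scatter) stays within the scatter.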

Compound 3, half-maximal cytotoxic concentration: 98600 nM
Compound 3: middle estimate off by 3.3-fold (0.52 log units), on the low side; the whole stated range lies below it.
By their numbers in this assay, from the lowest: compounds 2, 1 and 3 (each within the scatter of the next, the first and the last beyond it).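

On the aromatic carbon two atoms from the ring nitrogen and para to a large group, chloro in place of methyl is not a neutral swap: in this assay it gives a 2.9-fold higher number from compound 2 to compound 3 (0.46 log units; beyond the scatter) and so moves the number beyond the scatter, in the direction of lower toxicity in this test. The change involves one heavy atom for one heavy atom, with no ring, donor, acceptor or net charge entering or leaving, so even a change this small can register at this position, though the step is modest and is the only one of its kind available. Nothing available bears on why the number moves in this direction.

Going by these compounds, whether the step is particular to chloro remains open, and an amine, a methoxy group or a longer chain such as ethyl on the same carbon would show how the number responds to other groups at this position. Also open, on these data alone, is whether chloro in place of methyl gives a step of like size on the shared core as it stands in compound 1.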